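The compounds below may be only part of what the source reports. "The series", "measured", "known", "first", "only" and "open" are said of these compounds alone.

In a functional assay (QGY7701 cells, Homo sapiens) for inhibition, read by MTT assay, with a stated time of 48 h (a higher number here means a weaker inhibitor, a lower number a stronger inhibitor), compound 1 `COc1ccc2c(=O)c(/C=C/C(=O)Nc3cccc(Cl)c3)coc2c1` reaches only the limit of the assay, giving > 100000 nM. Compound 1 is thus known by a limit and not by a number (the limit of > 100000 nM in this assay, at which 1 of the 2 values shown sits). Going by the values given here, compound 2 `O=C(/C=C/c1coc2cc(O)ccc2c1=O)NCc1ccccc1` is the only other compound measured here, and in this assay compound 2 gives 63000 nM, a number rather than a limit. Among the compounds with values here, no two measured compounds differ in a single place, so no measured step is available to guide the change. Compound 3 `COc1ccc2c(=O)c(/C=C/C(=O)Nc3ccccc3)coc2c1` differs from compound 1 by hydrogen in place of chloro on an aromatic carbon, meta to a large group, turning the (3-chlorophenyl)amino group into an anilino group. The step is expected to be none beyond the scatter, a step that the limit leaves unreadable from compound 1 to compound 3, in either direction. Compound 3 is therefore estimated at 120000 nM, within a range from 40000 nM to 400000 nM, and a further limit rather than a number is judged the more likely outcome.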

Compound 3, half-maximal inhibitory concentration: 14000 nM
Estimate against measurement, compound 3: 8.6-fold (0.93 log units) above; the whole stated range lies above it.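

In this assay the chloro group on the aromatic carbon, meta to a large group, proves to matter: putting hydrogen in its place gives an at least 7.1-fold lower number from compound 1 to compound 3 (0.85 log units; beyond the scatter) and thus provides the only single-place comparison shown here. With this change, the anilino group of compound 3 goes with a measured number, whereas the (3-chlorophenyl)amino group of compound 1 goes with a limit. The step could be larger than printed, because compound 1 is known only by that limit: the limit of > 100000 nM in this assay, at which 1 of the 3 values shown sits.

With only chloro and hydrogen shown at this carbon, it remains open whether the difference is particular to chloro or would also appear with another group. Fluoro, methyl, methoxy or an amine at the same place could separate these possibilities.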